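This account rests on a few compounds, and the source may have more. Where it says the series, first, only, none or still open, it means among the compounds named here.

Compound 1 `CCOC(=O)/C(C#N)=C/c1ccc(O)c(O)c1` gives 57.8% in a functional assay on the whole organism (strain CD1) for inhibition, with Mus musculus as the target, with stated times of 15 min and 20 min, at a dose of 10 mg/kg by the subcutaneous route; a lower number here means less inhibition, a higher number more inhibition at the dose given (going by the name of the read-out).
Compound 2 `N#C/C(=C\c1ccc(O)c(O)c1)C(=O)N1CCOCC1` gives 40%.
Compound 3 `CC(C)(C)OC(=O)/C(C#N)=C/c1ccc(O)c(O)c1` gives 43.4%.

Among these three numbers compound 3 stands second highest; nearest to it is compound 2, a number 3.4 percentage points higher from compound 2 to compound 3 (within the scatter), and furthest is compound 1. Compound 4 `CC(C)CCOC(=O)/C(C#N)=C/c1ccc(O)c(O)c1` has not yet been measured and differs from compound 3 in one place: isopentyl in place of tert-butyl on an oxygen next to a carbonyl group. Among the compounds with values here, the only measured step that bears on this change is the exchange of ethyl for tert-butyl on an oxygen next to a carbonyl group, a number 14.4 percentage points lower from compound 1 to compound 3 (beyond the scatter). With a single alkyl exchange to go on, and isopentyl being neither of those groups, no step beyond the scatter is expected in this assay, a number 3.6 percentage points higher from compound 3 to compound 4 (within the scatter). Compound 4 is accordingly estimated at 47%, with a range from 33% to 61%.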

Compound 4, a percentage reported as inhibition, in the whole organism at one dose (the size of the read-out at that dose, not a potency): 27.2%
Compound 4: middle estimate off by 19.8 percentage points, on the high side, and the stated range ends above it.
By their numbers in this assay, from the lowest: compound 4; then compounds 2 and 3 (each within the scatter of the next); then compound 1.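

On an oxygen next to a carbonyl group, the alkyl group proves to matter more in this assay than the ethyl to tert-butyl exchange alone showed: isopentyl gives a further drop (a number 16.2 percentage points lower from compound 3 to compound 4 (beyond the scatter)) and the largest drop from the ethyl ester (a number 30.6 percentage points lower from compound 1 to compound 4 (beyond the scatter)). The isopentyl ester also falls below the morpholin-4-yl amide (a number 12.8 percentage points lower from compound 2 to compound 4 (beyond the scatter)). No evidence here accounts for this order.

As far as these compounds go, whether chain length or branching governs the number stays open, and a straight butyl or a benzyl group on that oxygen would bear on it.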